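The source may report more compounds than this note shows. Statements on the series, on what has been measured and on what is new or still open speak of the compounds shown alone.

Compound 1 `O=C(CSc1nnc(-c2ccncc2)o1)c1ccccc1`: 370 nM
Compound 2 `O=C(CSc1nnc(-c2ccnc(Cl)c2)o1)c1ccccc1`: 1290 nM
Compound 3 `O=C(CSc1nnc(-c2ccncc2)o1)c1ccc(Br)cc1`: 4230 nM

In a functional assay on MCF7 cells (Homo sapiens) for cytotoxicity, read by MTT assay and propidium iodide staining, with a stated time of 24 h (a higher number here means a weaker inhibitor, a lower number a stronger inhibitor), compound 3 gives the highest number of the three, 4230 nM, which makes it the weakest inhibitor measured so far. Compound 4 `O=C(CSc1nnc(-c2ccnc(Cl)c2)o1)c1ccc(Br)cc1` has not yet been measured. It differs from compound 3 in one place: chloro in place of hydrogen on an aromatic carbon. This is chloro in place of hydrogen on an aromatic carbon, turning pyridin-4-yl into 2-chloropyridin-4-yl.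

The same swap has been measured once, without the bromo group: a 3.5-fold higher number from compound 1 to compound 2 (0.54 log units; beyond the scatter). That modest step is the main guide here. The other measured step, an 11-fold higher number from compound 1 to compound 3 (1.06 log units; beyond the scatter), is the bromo swap itself, which compound 3 already carries. For the measured compounds named here, with only one example of the chloro swap, the data cannot show whether its effect holds when the bromo group is present. A modest move to a higher number, meaning a weaker inhibitor, is therefore expected, an estimated 2.4-fold higher number from compound 3 to compound 4 (0.37 log units; beyond the scatter). The expected value for compound 4 is 10000 nM, with an estimated range of 3000 nM to 30000 nM.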

Compound 4, half-maximal inhibitory concentration: 270 nM
Compound 4: middle estimate off by 37-fold (1.57 log units), on the high side; measured number outside the range, below it.
By their numbers in this assay, from the lowest: compounds 4 and 1 (each within the scatter of the next); then compound 2; then compound 3.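

In this assay, chloro next to the ring nitrogen has no fixed effect of its own: with the bromo group present, turning pyridin-4-yl into 2-chloropyridin-4-yl gives a 16-fold lower number from compound 3 to compound 4 (1.19 log units; beyond the scatter), a stronger inhibitor rather than a weaker one. Measured on the two cores, the chloro swap therefore runs in opposite directions: the same change on two cores in this assay, a 3.5-fold higher number (0.54 log units; beyond the scatter) from compound 1 to compound 2 and a 16-fold lower number (1.19 log units; beyond the scatter) from compound 3 to compound 4, 55-fold (1.74 log units) apart, beyond the scatter of two such steps

The bromo swap reverses too, with a 4.8-fold lower number from compound 2 to compound 4 (0.68 log units; beyond the scatter), so each group alone raises the number, while the two together leave compound 4 within the scatter of compound 1: the same change on two cores in this assay, an 11-fold higher number (1.06 log units; beyond the scatter) from compound 1 to compound 3 and a 4.8-fold lower number (0.68 log units; beyond the scatter) from compound 2 to compound 4, 55-fold (1.74 log units) apart, beyond the scatter of two such steps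

On these data alone, this reversal rests on a single set of four compounds, so how widely it holds remains open. An amine or a methyl group in place of the chloro, or fluoro in place of the bromo, would test whether it is tied to these two groups.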